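From a 4-(methylsulfanyl)phenyl group to a 3-cyanophenyl group

The source may report more compounds than this note shows. Statements on the series, on what has been measured and on what is new or still open speak of the compounds shown alone.

Compound 1 `O=C(CCc1cccc2c1B(O)OC2)Nc1cccc(I)c1`: 630 nM
Compound 2 `CSc1ccc(-c2cccc(NC(=O)CCc3cccc4c3B(O)OC4)c2)cc1`: 140 nM

In a functional assay on SK-OV-3 cells (Homo sapiens) for antiproliferative activity, read by MTT assay, with a stated time of 72 h (a higher number here means a weaker inhibitor, a lower number a stronger inhibitor), compound 2 gives 140 nM, the lower of the two numbers, which makes it the stronger inhibitor. Compound 3 `N#Cc1cccc(-c2cccc(NC(=O)CCc3cccc4c3B(O)OC4)c2)c1` keeps the shared core but carries 3-cyanophenyl in place of 4-(methylsulfanyl)phenyl on an aromatic carbon. Within the data shown here, the only measured step, a 4.5-fold lower number from compound 1 to compound 2 (0.65 log units; beyond the scatter), was modest and exchanged iodo for 4-(methylsulfanyl)phenyl, so it says little about one such group replacing another. Among the measured compounds shown here, no measured compound carries a nitrile, so only a small rise, within the scatter, is expected: a 1.4-fold higher number from compound 2 to compound 3 (0.15 log units; within the scatter). For compound 3 the estimated value is 200 nM, with an expected range of 70 nM to 600 nM.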

Compound 3, half-maximal inhibitory concentration: 120 nM
Beside the measured number, compound 3's estimate is 1.7-fold (0.22 log units) above it; the measured number falls inside the stated range.
By their numbers in this assay, from the lowest: compounds 3 and 2 (each within the scatter of the next); then compound 1.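

Exchanging 4-(methylsulfanyl)phenyl for 3-cyanophenyl leaves the number essentially unchanged (a 1.2-fold lower number from compound 2 to compound 3 (0.07 log units; within the scatter)), so two differently substituted phenyl groups read alike at this position. Replacing iodo with 3-cyanophenyl also lowers the number (a 5.3-fold lower number from compound 1 to compound 3 (0.72 log units; beyond the scatter)), so the drop seen from compound 1 is not confined to a single phenyl group. Nothing measured here explains this result.

From the compounds shown here alone, whether a plain phenyl ring would serve equally well remains open. So does whether groups without an aromatic ring, such as an amine or a carboxylic acid, would be tolerated here.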